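A few compounds are considered here, and "the series" means these few. Any claim that something is new, unique, unknown or untested is made for them only; others in the source may bear on it.

Measured in a functional assay on HCT-8 cells (Homo sapiens) for antiproliferative activity, read by MTT assay, with a stated time of 48 h; a higher number here means a weaker inhibitor, a lower number a stronger inhibitor:
- compound 1 `COc1ccc(C(=O)c2ccc(OC)c3c2C=CC(C)(C)O3)c(NC(=O)CO)c1`: 630 nM
- compound 2 `COc1ccc(C(=O)c2ccc(OC)c3c2C=CC(C)(C)O3)c(NC(=O)CN)c1`: 1050 nM
- compound 3 `CNCC(=O)Nc1cc(OC)ccc1C(=O)c1ccc2c(c1)C=CC(C)(C)O2`: 1010 nM

The three numbers sit close together, and compound 2 lies within the scatter of both others, so it cannot be ranked against them. Compound 4 `COc1ccc(C(=O)c2ccc(OC)c3c2C=CC(C)(C)O3)c(NC(=O)CN(C)C)c1` keeps the core of compound 2 but carries dimethylamino in place of amino on a saturated chain carbon bound to a carbonyl carbon.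

Among the measured compounds shown here, only one measured step touches this place on the chain. It is a 1.7-fold higher number from compound 1 to compound 2 (0.22 log units; within the scatter), and it swaps hydroxy for amino rather than adding to the amine. For the measured compounds named here, compound 3, at 1010 nM, differs from compound 2 in more than one place and gives no clean step, though its value stays in the same range. With so small a step at this place, no change beyond the scatter is expected in this assay. The expected step is a 1.1-fold lower number from compound 2 to compound 4 (0.02 log units; within the scatter). Compound 4 is estimated at 1000 nM, with an expected range of 450 nM to 2300 nM.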

Compound 4, half-maximal inhibitory concentration: 5660 nM
Beside the measured number, compound 4's estimate is 5.7-fold (0.75 log units) below it; the whole stated range lies below it.
By their numbers in this assay, from the lowest: compounds 1, 3 and 2 (each within the scatter of the next); then compound 4.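

Among the compounds shown here, at the saturated chain carbon bound to a carbonyl carbon, this assay does respond to the group carried: dimethylamino in place of amino gives a 5.4-fold higher number from compound 2 to compound 4 (0.73 log units; beyond the scatter), the first step at this place beyond the scatter. Dimethylamino in place of hydroxy gives a 9.0-fold higher number from compound 1 to compound 4 (0.95 log units; beyond the scatter), also beyond the scatter, whereas amino in place of hydroxy gave a 1.7-fold higher number from compound 1 to compound 2 (0.22 log units; within the scatter) and stayed within it, so among these three groups only dimethylamino stands apart. No measurement shown here accounts for this step.

The compounds shown leave open whether the higher number goes with dimethylamino alone or extends to other substituted amines at this place. A diethylamino group or a morpholine ring on the same chain carbon, on the core of compound 2, would bear on that question.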